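A few compounds are considered here, and "the series" means these few. Any claim that something is new, unique, unknown or untested is made for them only; others in the source may bear on it.

Three compounds have a value in an ADME assay on the whole organism (serum) with Homo sapiens as the target; a lower number here means that the compound disappears faster, a higher number that the compound lasts longer. Compound 1 `Cc1cn(C2CC(N=[N+]=[N-])C(COC(=O)NCCCC(=O)O)O2)c(=O)[nH]c1=O` stops at a limit of the assay, > 48 h. Compound 2 `CCCCOC(=O)OCC1OC(n2cc(C)c(=O)[nH]c2=O)CC1N=[N+]=[N-]` gives 0.15 h. Compound 3 `Cc1cn(C2CC(N=[N+]=[N-])C(COC(=O)NCCCO)O2)c(=O)[nH]c1=O` likewise stops at a limit, > 48 h.

Compound 3 therefore stands at the upper edge of what the measurement reports, a position it shares with compound 1 (the limit of > 48 h in this assay, at which 2 of the 3 values shown sit). The unmeasured compound 4 `Cc1cn(C2CC(N=[N+]=[N-])C(COC(=O)NCCCN)O2)c(=O)[nH]c1=O` differs from compound 3 by amino in place of hydroxy on a saturated chain carbon, three bonds along the chain from an amide-type nitrogen. Among the compounds with values here, the one measured step at this same chain position, a step that the two limits leave unreadable from compound 1 to compound 3, cannot be read because both ends are limits. The two large steps, an at least 320-fold lower number from compound 1 to compound 2 (2.50 log units; beyond the scatter) and an at least 320-fold higher number from compound 2 to compound 3 (2.50 log units; beyond the scatter), change the group on the carbonyl carbon, not the end of the chain, and so bear only indirectly on the present change. On this basis no step beyond the scatter is expected for compound 4 in this assay. Compound 4 is estimated at 60 h, with a range from 30 h to 120 h. The step that the limit leaves unreadable from compound 3 to compound 4 is expected to be small, and the result is most likely to be reported again as a limit.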

Compound 4, half-life: > 48 h
Compound 4: no number, only a limit; the forecaster's own chance of this, stated with the estimate: 70%; the middle value does not contradict the limit.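

Compound 4 also sits at the edge of what this assay reports, a value that is a limit and not a number: the limit of > 48 h in this assay, at which 3 of the 4 values shown sit. The steps to compound 4 from compound 1 and from compound 3 have limits at both ends and cannot be read. What the result adds is that amino, as well as carboxy and hydroxy, goes with this limit at this chain position, and (3-aminopropyl)amino in place of butoxy on a carbonyl carbon gives an at least 320-fold higher number from compound 2 to compound 4 (2.50 log units; beyond the scatter).

As far as these compounds go, how long compound 1, compound 3 and compound 4 last past the limit remains open, so no order can be given among carboxy, hydroxy and amino. Also open, from the compounds shown here alone, is whether a longer chain or a dimethylamino group on that saturated chain carbon would stay at the limit.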